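A few compounds are considered here, and "the series" means these few. Any claim that something is new, unique, unknown or untested is made for them only; others in the source may bear on it.

Series notes. Compound 1 `O=C1CN(C2CCCC2)c2nc(Nc3ccc(N4CCCCC4)cc3)ncc2N1` is the parent of the set; in a functional assay on MDA-MB-231 cells (Homo sapiens) for inhibition, read by MTT assay, with a stated time of 48 h (on this read-out lower numbers stand for stronger inhibition and higher numbers for weaker inhibition), compound 1 gives 25000 nM. Compound 2 `CC1CCN(c2ccc(Nc3ncc4c(n3)N(C3CCCC3)CC(=O)N4)cc2)CC1` carries the change methyl in place of hydrogen on a saturated ring carbon on the core of compound 1, and in this assay compound 2 gives 22700 nM. The step of a 1.1-fold lower number from compound 1 to compound 2 (0.04 log units; within the scatter) leaves the read-out essentially where it was. Compound 3 `CCN1C(=O)CN(C2CCCC2)c2nc(Nc3ccc(N4CCCCC4)cn3)ncc21` has a different core; how its core differs from the core of compound 1 is not broken down here. In this assay compound 3 gives 28200 nM, which sits with the values of compound 1 and compound 2 inside the usual scatter, so no order among the three can be stated.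

Compound 4 `CCN1C(=O)CN(C2CCCC2)c2nc(Nc3ccc(N4CCC(C)CC4)cn3)ncc21` is not yet measured. It stands to compound 3 as compound 2 stands to compound 1: the change methyl in place of hydrogen on a saturated ring carbon falls at a place described in the same words as for compound 2, so it is the same change, made on another core. Among the compounds with values here, the only evidence for its size is the single earlier step, and that step lay within the scatter. The expected step of a 1.1-fold lower number from compound 3 to compound 4 (0.04 log units; within the scatter) is therefore small, because a 1.1-fold lower number from compound 1 to compound 2 (0.04 log units; within the scatter) lay within the scatter. The estimate rests on compound 3 at 28200 nM as the starting value. For compound 4 the estimate in this assay is 26000 nM, expected to fall between 13000 nM and 52000 nM.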

Compound 4, half-maximal inhibitory concentration: > 30000 nM
Compound 4 gave a limit, no number; the forecaster's own chance of this, stated with the estimate: 15%; middle value at least 1.1-fold (0.06 log units) from the limit.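

In this assay compound 4 gives > 30000 nM, which is a limit of the assay and not a number: the limit of > 30000 nM in this assay, at which 1 of the 4 values shown sits. Within the data shown here, on the core of compound 3, the change from piperidin-1-yl to 4-methylpiperidin-1-yl gives an at least 1.0-fold higher number from compound 3 to compound 4 (0.02 log units; that floor lies within the scatter), which fixes only one side of the step and leaves its full size unknown. Set beside the earlier step, this result shows neither that the change carries over from one core to the other with the same size nor that its size differs between them: the same change on two cores in this assay, a 1.1-fold lower number (0.04 log units; within the scatter) from compound 1 to compound 2 and an at least 1.0-fold higher number (0.02 log units; that floor lies within the scatter) from compound 3 to compound 4; the limit leaves it open whether they differ.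

The compounds shown leave open whether a different group at this place on the six-membered ring, such as an amine, a carboxylic acid or a longer chain, would move the read-out beyond the scatter on either core. They also leave open the true size of the step on the core of compound 3, which only a numerical value for compound 4 in place of the limit could settle.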